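The source may report more compounds than this note shows. Statements on the series, on what has been measured and on what is new or still open speak of the compounds shown alone.

Compound 2 `Nc1ccccc1NC(=O)/C=C/c1ccc(CSc2ccc(Cl)cc2)cc1` stands at the low end of the three measured numbers. In a functional assay on HCT-116 cells (Homo sapiens) for inhibition, read by CCK-8 assay, with a stated time of 72 h, tested at 8 uM (a lower number here means less inhibition of growth, a higher number more inhibition of growth at the concentration tested), compound 2 gives 3.27%. Compound 1 `Cc1ccc(SCc2ccc(/C=C/C(=O)Nc3ccccc3N)cc2)cc1` gives 4.93% in this assay, a number within the scatter of compound 2, while compound 3 `Nc1ccccc1NC(=O)c1ccc(CSc2ccc(C(F)(F)F)cn2)cc1` gives 25.8% in this assay, a number beyond the scatter. Compound 4 `CC(C)(C)c1ccc(SCc2ccc(/C=C/C(=O)Nc3ccccc3N)cc2)cc1` has not yet been measured; it differs from compound 2 in one place, (tert-butyl in place of chloro on an aromatic carbon). Among the compounds with values here, the only measured step at this same aromatic carbon is a number 1.7 percentage points lower from compound 1 to compound 2 (within the scatter), which stayed within the scatter; no step that brings in tert-butyl has been measured. Since the exchange of methyl for chloro moved the number little, no step beyond the scatter is expected, and the step of a number 2.7 percentage points higher from compound 2 to compound 4 (within the scatter) is the estimate. Compound 4 is therefore expected to give 6%, with a range from 0% to 16%.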

Compound 4, percent growth inhibition at one concentration: 39%
The estimate for compound 4 lay 33 percentage points below the measured number, outside the stated range (above it).
By their numbers in this assay, from the lowest: compounds 2 and 1 (each within the scatter of the next); then compound 3; then compound 4.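

In this assay, tert-butyl in place of chloro gives a number 35.7 percentage points higher from compound 2 to compound 4 (beyond the scatter), and tert-butyl in place of methyl gives a number 34.1 percentage points higher from compound 1 to compound 4 (beyond the scatter). So this aromatic carbon is not indifferent to its group, as the methyl and chloro compounds alone suggested: they read alike, while the tert-butyl compound stands well apart. Nothing available explains this jump.

From the compounds shown here alone, what an isopropyl or a methoxy group would give at this carbon stays open, so the path from methyl to tert-butyl is unknown. Also open, going by these compounds, is whether tert-butyl would act the same way on the core of compound 3.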